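The source may hold more compounds than are shown below. What is called first, only, known or untested is meant among the compounds shown, and "the series" means these compounds.

In an ADME assay on BEAS-2B cells (Homo sapiens) for cytotoxicity, read by MTT assay, with a stated time of 72 h (a higher number here means a weaker inhibitor, a lower number a stronger inhibitor), compound 2 `CCCCOC1OC(=O)C(Cl)=C1Cl` gives 22300 nM. Compound 1 `CC(C)OC1OC(=O)C(Cl)=C1Cl` gives 27500 nM, and the step between the two is a 1.2-fold lower number from compound 1 to compound 2 (0.09 log units; within the scatter). Compound 3 `CC(C)(C)COC1OC(=O)C(Cl)=C1Cl` gives 59000 nM, and it stands apart with a 2.6-fold higher number from compound 2 to compound 3 (0.42 log units; beyond the scatter).

Compound 4 `CC(C)(C)OC1OC(=O)C(Cl)=C1Cl` is not yet measured. Its difference from compound 2 is tert-butyl in place of butyl on an oxygen on a saturated carbon. In words, this is tert-butyl in place of butyl on an oxygen on a saturated carbon.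

Among the compounds with values here, two measured steps bear on this change. Butyl in place of isopropyl on the same oxygen gave a 1.2-fold lower number from compound 1 to compound 2 (0.09 log units; within the scatter), so exchanging these groups on that oxygen has so far left the number unmoved. The tert-butyl group has also been seen once, on a saturated chain carbon bound to that oxygen, where it gave a 2.6-fold higher number from compound 2 to compound 3 (0.42 log units; beyond the scatter). Neither step places tert-butyl directly on the oxygen, so the second carries over only in part. A slightly higher number is expected, though probably no step beyond the scatter. The expected step is a 1.6-fold higher number from compound 2 to compound 4 (0.20 log units; within the scatter). For compound 4 the estimated value is 35000 nM, with an expected range of 16000 nM to 75000 nM.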

Compound 4, half-maximal inhibitory concentration: 23100 nM
Estimate against measurement, compound 4: 1.5-fold (0.18 log units) above; low and high end bracket the measured number.
By their numbers in this assay, from the lowest: compounds 2, 4 and 1 (each within the scatter of the next); then compound 3.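

In this assay, tert-butyl placed directly on the oxygen leaves the number unmoved, with a 1.0-fold higher number from compound 2 to compound 4 (0.02 log units; within the scatter) and a 1.2-fold lower number from compound 1 to compound 4 (0.08 log units; within the scatter), so butyl, isopropyl and tert-butyl on this oxygen all lie within the scatter of one another. Within the data shown here, the tert-butyl group alone therefore does not carry a rise in the number: the only step beyond the scatter remains a 2.6-fold higher number from compound 2 to compound 3 (0.42 log units; beyond the scatter), where tert-butyl stands on a saturated chain carbon bound to that oxygen, and this modest step goes against an otherwise flat picture across the series. Among these compounds, no supporting measurement is available to account for either the flat result on the oxygen or the one higher value.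

Open, on these data alone, is whether the flat picture holds for groups of another kind on this oxygen, such as a longer chain, a benzyl group or a chain ending in an amine or a carboxylic acid. Also open, as far as these compounds go, is whether the higher number of compound 3 marks the start of a trend or stands alone, and how changes to the shared core itself would compare with changes on the oxygen.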